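The source may report more compounds than this note shows. Statements on the series, on what has been measured and on what is new or still open speak of the compounds shown alone.

Three measured members of the series share an amide-linked core. Compound 1 `COc1ccc(-c2cnc(NC(=O)c3ccc(F)cc3)n2C(C)C)cc1` carries a fluorophenyl amide; in a toxicity assay on THP-1 cells (Homo sapiens) for inhibition (on this read-out lower numbers stand for higher toxicity in this test and higher numbers for lower toxicity in this test), compound 1 is reported only at > 50000 nM, which is a limit of the test and not a number. Compound 3 `Cn1c(-c2ccc(Cl)cc2)cnc1NC(=O)c1ncc[nH]1` carries an imidazolyl amide, and in this assay compound 3 gives 52000 nM. Compound 2 `COc1ccc(-c2cnc(NC(=O)c3cnc[nH]3)n2C)cc1` is the closest neighbour of the unmeasured compound; in this assay compound 2 is likewise reported only as a limit, > 100000 nM. Among the compounds with values here, its standing among the three is therefore known only as a bound, (the limit of > 100000 nM in this assay, at which 1 of the 3 values shown sits), alongside the other bound, (the limit of > 50000 nM in this assay, at which 1 of the 3 values shown sits), with the single numeric value of compound 3 sitting close to both. Within the data shown here, no pair of measured compounds differs in a single place, so no measured step is available.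

Compound 4 `COc1ccc(-c2cnc(NC(=O)c3ccccc3Cl)n2C)cc1` arises from compound 2 by 2-chlorophenyl in place of 1H-imidazol-5-yl on a carbonyl carbon. Compound 1, which carries an aryl amide, and compound 3, which carries an imidazolyl amide, both sit at the weakly toxic end of the read-out, so no step beyond the scatter is expected in either direction, and the expected step is an at least 1.6-fold lower number from compound 2 to compound 4 (0.22 log units; that floor lies within the scatter). Compound 4 is expected to give about 60000 nM, within 20000 nM to 200000 nM, most probably once more as a limit.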

Compound 4, half-maximal cytotoxic concentration: > 50000 nM
Compound 4: no number, only a limit (the forecaster's own chance of this, stated with the estimate: 60%); the middle value lies beyond the limit too.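

In this assay, within the data shown here, compound 2 and compound 4 are both reported only as limits of the test, so no step between them can be read. The compounds shown leave open whether 2-chlorophenyl in place of 1H-imidazol-5-yl on a carbonyl carbon shifts this read-out at all, and in which direction.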